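The compounds below may be only part of what the source reports. "The series", "measured", "known", "first", "only" and "open" are said of these compounds alone.

Series notes. Compound 1 `CCCc1nc(CC)c(C(=O)OCCCN2C(=O)c3ccccc3C2=O)n1Cc1ccc(-c2ccccc2S(=O)(=O)NC(=O)OCCC(C)C)cc1F` is measured in an assay on isolated protein for binding affinity to Type-2 angiotensin II receptor (Homo sapiens) (on this read-out higher numbers stand for weaker inhibition and lower numbers for stronger inhibition), at 3 nM. Two further compounds sit on the same read-out: compound 3 `CCCCCOC(=O)NS(=O)(=O)c1ccccc1-c1ccc(Cn2c(CCC)nc(CC)c2C(=O)OCCC(=O)Nc2ccccc2)c(F)c1` gives 1 nM, and compound 2 `CCCc1nc(CC)c(C(=O)OCc2cccc(C(=O)N(c3ccccc3)c3ccccc3)c2)n1Cc1ccc(-c2ccccc2-c2nn[nH]n2)cc1` gives 300 nM. Compound 1 thus stands second highest of the three numbers, above compound 3 by a gap beyond the usual scatter and far below compound 2.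

The next compound, compound 4 `CCCc1nc(CC)c(C(=O)OCCN2C(=O)c3ccccc3C2=O)n1Cc1ccc(-c2ccccc2S(=O)(=O)NC(=O)OCCC(C)C)cc1F`, differs from compound 1 only in the linker: a group of 11 heavy atoms (8 carbon, 1 nitrogen, 2 oxygen; one five-membered non-aromatic ring with 1 hetero atom, one six-membered aromatic ring of carbon only) in place of a group of 12 heavy atoms (9 carbon, 1 nitrogen, 2 oxygen; one five-membered non-aromatic ring with 1 hetero atom, one six-membered aromatic ring of carbon only), on a saturated chain carbon, two bonds along the chain from an oxygen next to a carbonyl group. Among the measured compounds shown here, no measured pair in the set isolates a change of this kind, so the expected step in this assay is small, likely within the scatter, with at most a slight move toward a higher number.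

Compound 4 is therefore expected near 4 nM, in the range 1.5 nM to 12 nM, which would mean a step of a 1.3-fold higher number from compound 1 to compound 4 (0.12 log units; within the scatter).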

Compound 4, half-maximal inhibitory concentration: 7 nM
Beside the measured number, compound 4's estimate is 1.8-fold (0.24 log units) below it, and the stated range covers the measured number.
By their numbers in this assay, from the lowest: compound 3; then compound 1; then compound 4; then compound 2.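

In this assay, among the compounds shown here, the group of 11 heavy atoms in place of the group of 12 heavy atoms gives a 2.3-fold higher number from compound 1 to compound 4 (0.37 log units; beyond the scatter) and is the first single-place step. This position on a saturated chain carbon is therefore sensitive to the change, though the step is modest. No available evidence bears on the origin of the step. Going by these compounds, with only these two chain lengths compared, the direction of the effect for a longer chain remains open. Also open, on these data alone, is how an amine or a carboxylic acid would read at this position.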